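The compounds below may be only part of what the source reports. "The series", "measured", "known", "first", "only" and "open" are said of these compounds alone.

Measured so far in a functional assay on MCF7 cells (Homo sapiens) for antiproliferative activity, read by MTT assay, with a stated time of 24 h; on this read-out lower numbers stand for stronger inhibition and higher numbers for weaker inhibition:
compound 1, `CCn1c(C(=O)NCCC(=O)OC)ccc1C(CC)(CC)c1ccc(OCS(=O)(=O)c2ccccc2)c(C)c1`, gives > 50000 nM, which is a limit of the assay rather than a number.
compound 2, `CCN(CC)CCNC(=O)c1ccc(C(CC)(CC)c2ccc(OCS(=O)(=O)c3ccccc3)c(C)c2)n1CC`, gives 4680 nM.
compound 3, `CCn1c(C(=O)NCC(=O)O)ccc1C(CC)(CC)c1ccc(OCS(=O)(=O)c2ccccc2)c(C)c1`, gives 33100 nM.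

Among the numbers shown, compound 3 stands highest, that is weakest; its nearest neighbour is compound 2, and the step of a 7.1-fold higher number from compound 2 to compound 3 (0.85 log units; beyond the scatter) is a modest worsening. The step from compound 1 to compound 3, with compound 1 sitting at the limit (the limit of > 50000 nM in this assay, at which 1 of the 3 values shown sits), reads an at least 1.5-fold lower number from compound 1 to compound 3 (0.17 log units; that floor lies within the scatter), and its floor lies within the scatter, so the ester-to-acid change is not clearly telling.

Compound 4, `CCn1c(C(=O)N[C@H](CCC(=O)O)C(=O)O)ccc1C(CC)(CC)c1ccc(OCS(=O)(=O)c2ccccc2)c(C)c1`, has not been measured. It differs from compound 3 in this way: 2-carboxyethyl in place of hydrogen on a saturated chain carbon bound to an amide-type nitrogen and a carbonyl carbon.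

The measured steps that bear on this change are those around the chain attached to the amide-type nitrogen. A carboxy group in place of the basic (diethylamino)methyl cost potency, a 7.1-fold higher number from compound 2 to compound 3 (0.85 log units; beyond the scatter), while swapping an ester for a carboxy did little, an at least 1.5-fold lower number from compound 1 to compound 3 (0.17 log units; that floor lies within the scatter). Adding a second carboxylic acid as 2-carboxyethyl moves further in the acid direction, so the expectation in this assay is a small worsening or no change beyond the scatter, with a real chance that only a limit is reported. For compound 4 the estimate is 42000 nM, between 15000 nM and 120000 nM, which corresponds to an expected step of a 1.3-fold higher number from compound 3 to compound 4 (0.10 log units; within the scatter).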

Compound 4, half-maximal inhibitory concentration: > 50000 nM
Compound 4: a limit, no number (the forecaster's own chance of this, stated with the estimate: 40%); middle value at least 1.1-fold (0.07 log units) from the limit.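

In this assay compound 4 gives a limit rather than a number, the second such result in this set: the limit of > 50000 nM in this assay, at which 2 of the 4 values shown sit. Putting 2-carboxyethyl on the saturated chain carbon bound to an amide-type nitrogen and a carbonyl carbon gives an at least 1.5-fold higher number from compound 3 to compound 4 (0.17 log units; that floor lies within the scatter), so this second carboxylic acid cannot be said to have made compound 3 any weaker, although the true gap could be larger than that floor. The clear contrast is with the amine-bearing compound 2, since replacing its 2-(diethylamino)ethyl group with 1,3-dicarboxypropyl gives an at least 10-fold higher number from compound 2 to compound 4 (1.02 log units; beyond the scatter), which extends the evidence that carboxylic acids on this amide nitrogen chain go with much weaker results than the diethylamino chain does.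

Compound 1 and compound 4 both sit at limits, so the step between them cannot be read, and the ester and the diacid stay unranked. The compounds shown also leave open whether a chain ending in a smaller amine such as dimethylamino, or a longer chain ending in diethylamino, would match or improve on compound 2.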